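This account rests on a few compounds, and the source may have more. Where it says the series, first, only, none or still open, it means among the compounds named here.

Compound 1, `C/C=C/C=C/C(=O)N(Cc1ccc(OC)c(O)c1)c1cc(OC)c(OC)c(OC)c1`, was tested in a functional assay on HCT-116 cells (Homo sapiens) for inhibition, read by MTT assay, with a stated time of 48 h (on this read-out higher numbers stand for weaker inhibition and lower numbers for stronger inhibition), where compound 1 gives 180 nM. This is the lowest of the three numbers measured. Compound 2, `COc1cc(NCc2cccc(O)c2)cc(OC)c1OC`, gives 67700 nM, and compound 3, `COc1ccc(CNc2cc(OC)c(OC)c(OC)c2)cc1F`, gives 32200 nM; both lie well beyond the scatter from compound 1, so compound 1 is the most potent of the three measured here. Within the data shown here, no two of the measured compounds differ in only one place, so no single-change step is available for comparison.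

Compound 4, `C/C=C/C(=O)N(Cc1ccc(OC)c(O)c1)c1cc(OC)c(OC)c(OC)c1`, differs from compound 1 in one place: methyl in place of prop-1-en-1-yl on a double-bonded chain carbon bound to a double-bonded chain carbon. Compound 1 shares the same core and the same amide with compound 4; only the chain on the carbonyl is shortened.

Among the measured compounds shown here, since no measured pair shows what such a shortening does, the expectation rests on compound 1 alone. The step in this assay a 2.2-fold higher number from compound 1 to compound 4 (0.35 log units; beyond the scatter) is expected to be modest, toward a somewhat higher number. Compound 4 is thus estimated to give 400 nM, with a range from 120 nM to 1500 nM.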

Compound 4, half-maximal inhibitory concentration: 55 nM
The estimate for compound 4 lay 7.3-fold (0.86 log units) above the measured number, and the stated range ends above it.
By their numbers in this assay, from the lowest: compound 4; then compound 1; then compound 3; then compound 2.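

Removing part of the chain on the carbonyl, penta-1,3-dien-1-yl to prop-1-en-1-yl, brings no loss of activity in this assay but gives a 3.3-fold lower number from compound 1 to compound 4 (0.51 log units; beyond the scatter). The full penta-1,3-dien-1-yl chain is therefore not needed for activity on this shared core, and the shorter chain gives the lowest of the four numbers. No measurement bearing on the reason for this gain is available.

From the compounds shown here alone, a single step sets no trend, so it remains open whether a still shorter acetyl group or a saturated butanoyl chain on the same amide nitrogen would continue the gain or reverse it. What the carbonyl contributes also stays unresolved, since compound 2 and compound 3 differ from compound 1 in more than one place.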